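A tert-Butyl Amide Facing the Ceiling of the Assay

This account rests on a few compounds, and the source may have more. Where it says the series, first, only, none or still open, it means among the compounds named here.

Measured compounds:
compound 1, `C=CC1=C(C(=O)O)C(c2ccc(F)cc2)OC1`, 67400 nM
compound 2, `C=CC1=C(C(=O)NC(C)(C)C)C(c2ccc(OC)cc2)OC1`, > 100000 nM
compound 3, `C=CC1=C(C(=O)NCC(C)C)C(c2ccc(F)cc2)OC1`, > 100000 nM

In a functional assay on HeLa cells (Homo sapiens) for cytotoxicity, read by MTT assay, with a stated time of 24 h (a higher number here means a weaker inhibitor, a lower number a stronger inhibitor), compound 1 gives 67400 nM. For compound 3 the result is only a limit, > 100000 nM. For compound 2 the result is likewise a limit, > 100000 nM. Compound 3 therefore stands at the ceiling, together with compound 2, because of the limit of > 100000 nM in this assay, at which 2 of the 3 values shown sit. For the measured compounds named here, the single measured step, an at least 1.4-fold higher number from compound 1 to compound 3 (0.17 log units; that floor lies within the scatter), replaces the acid by the isobutylamide and its floor lies within the scatter.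

Compound 4, `C=CC1=C(C(=O)NC(C)(C)C)C(c2ccc(F)cc2)OC1`, differs from compound 3 by tert-butyl in place of isobutyl on an amide-type nitrogen. Going by the values given here, no measured step bears on this exchange of one branched four-carbon chain for another on the amide nitrogen, and compound 2, which already carries the tert-butylamide on a different aryl group, sits at the same limit. The step that the limit leaves unreadable from compound 3 to compound 4 is therefore expected to be none beyond the scatter. Compound 4 is estimated at 150000 nM, within 50000 nM to 500000 nM, most likely reported again as a limit.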

Compound 4, half-maximal inhibitory concentration: > 100000 nM
Compound 4 gave a limit, no number; the forecaster's own chance of this, stated with the estimate: 85%; the middle value is on the limit's open side.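

Compound 4 is a third amide at the ceiling: in this assay, compound 4 gives only a limit, > 100000 nM. Placing (tert-butyl)amino instead of hydroxy on the carbonyl carbon gives an at least 1.4-fold higher number from compound 1 to compound 4 (0.17 log units; that floor lies within the scatter), so this change, like the isobutylamide before it, shows no step beyond the scatter. The steps linking compound 4 to compound 2 and compound 3 cannot be read, so neither tert-butyl in place of isobutyl nor fluoro in place of methoxy can be sized, because all three amides share one ceiling: the limit of > 100000 nM in this assay, at which 3 of the 4 values shown sit.

The compounds shown leave open whether any amide at this carbonyl truly differs from the acid of compound 1. They also leave open whether a methylamide, or a longer chain ending in an amine on the amide nitrogen, would give a value under the ceiling.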